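The compounds below may be only part of what the source reports. "The series", "measured", "known", "first", "only" and "open" are said of these compounds alone.

Values in a functional assay on NCI-H460 cells (Homo sapiens) for antiproliferative activity, read by CCK-8 assay, with a stated time of 72 h; a lower number here means a stronger inhibitor, a higher number a weaker inhibitor:
- Compound 1 `CCC(C)n1cnc2c(NCc3ccc(C(=O)Nc4ccccc4N)cc3)nc(Cl)nc21`: 4940 nM
- Compound 2 `Cc1ccc(Nc2nc(Cl)nc3c2ncn3Cc2ccc(C(=O)Nc3ccccc3N)cc2)cc1`: 1590 nM
- Compound 3 `Nc1ccccc1NC(=O)c1ccc(Cn2cnc3c(Nc4ccccc4)nc(Cl)nc32)cc1`: 5740 nM

In this assay, compound 3 at 5740 nM lies within the scatter of compound 1 and well beyond the scatter of compound 2. Compound 4 `Nc1ccccc1NC(=O)c1ccc(Cn2cnc3c(NCc4ccccc4)nc(Cl)nc32)cc1` differs from compound 3 as follows: benzyl in place of phenyl on a nitrogen on an aromatic ring. This turns anilino into benzylamino. Within the data shown here, the only measured step touching this aromatic group is the modest 3.6-fold higher number from compound 2 to compound 3 (0.56 log units; beyond the scatter), which is a hydrogen in place of methyl. Among the measured compounds shown here, no measured step exchanges phenyl for benzyl, so the data give no direction, and no shift beyond the scatter is expected. The expected change is a 1.3-fold lower number from compound 3 to compound 4 (0.11 log units; within the scatter). For compound 4 the estimated value is 4500 nM, with an expected range of 1600 nM to 12000 nM.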

Compound 4, half-maximal inhibitory concentration: 11200 nM
Beside the measured number, compound 4's estimate is 2.5-fold (0.40 log units) below it; low and high end bracket the measured number.
By their numbers in this assay, from the lowest: compound 2; then compounds 1, 3 and 4 (each within the scatter of the next, the first and the last beyond it).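

Phenyl and benzyl on this nitrogen are not separated in this assay: the anilino to benzylamino change gives a 2.0-fold higher number from compound 3 to compound 4 (0.29 log units; within the scatter), so this position accepts benzyl without a shift beyond the scatter. Benzyl in place of 4-methylphenyl gives a 7.0-fold higher number from compound 2 to compound 4 (0.85 log units; beyond the scatter), which keeps compound 2 apart from both unsubstituted aromatic groups at this nitrogen. No evidence on the origin of either step is available.

Among these compounds, whether a methyl group on the benzyl ring would produce a step like the one between compound 3 and compound 2 remains open. As far as these compounds go, the effect of a longer chain, such as phenethyl, on this nitrogen also remains open.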